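Cytotoxicity in PC-12 Cells: From Compound 3 to Compound 4

The compounds below may be only part of what the source reports. "The series", "measured", "known", "first", "only" and "open" are said of these compounds alone.

Measured so far:
compound 1 `CC(C)c1ccc(-n2nc(-c3ccc(C(F)(F)F)cc3O)nc2-c2ccccc2O)cc1`: 108%
compound 2 `Oc1cc(C(F)(F)F)ccc1-c1nc(-c2ccccc2O)n(-c2ccc(Cl)cc2)n1`: 96.1%
compound 3 `Oc1cc(C(F)(F)F)ccc1-c1nc(-c2ccccc2O)n(-c2ccccc2Cl)n1`: 102%

In a functional assay on PC-12 cells (Rattus norvegicus) for cytotoxicity, read by MTT assay, with stated times of 2 h and 24 h, tested at 10 uM (on this read-out lower numbers stand for a weaker effect and higher numbers for a stronger effect at the one concentration tested), compound 3 gives 102%, the second highest of the three numbers; its gaps to compound 2 and to compound 1 both lie within the scatter. Compound 4 `Oc1cc(C(F)(F)F)ccc1-c1nc(-c2ccccc2O)n(-c2ccc(Cl)cc2Cl)n1` differs from compound 3 by chloro in place of hydrogen on an aromatic carbon. Going by the values given here, two measured steps bear on this change: a number 5.9 percentage points higher from compound 2 to compound 3 (within the scatter), where 2-chlorophenyl replaced 4-chlorophenyl, and a number 11.9 percentage points lower from compound 1 to compound 2 (beyond the scatter), where a chloro replaced an isopropyl. Neither step added a chloro to a phenyl already carrying one, and nothing among them points to a move beyond the scatter. For compound 4 the expected step is a number 2 percentage points lower from compound 3 to compound 4 (within the scatter). Compound 4 is therefore estimated at 100%, between 85% and 115%.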

Compound 4, a percentage reported as activity, at one concentration (the size of the read-out at that concentration, not a potency): 95.2%
Compound 4: middle estimate off by 4.8 percentage points, on the high side; the range from low to high includes it.
By their numbers in this assay, from the lowest: compounds 4, 2, 3 and 1 (each within the scatter of the next, the first and the last beyond it).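

In this assay, the second chloro that makes the 2,4-dichlorophenyl gives a number 6.8 percentage points lower from compound 3 to compound 4 (within the scatter), and added to the other monochloro compound it gives a number 0.9 percentage points lower from compound 2 to compound 4 (within the scatter). A phenyl already carrying one chloro thus takes a second with no change beyond the scatter, whichever chloro was there first. Only the exchange for 4-isopropylphenyl leaves the scatter, with a number 12.8 percentage points lower from compound 1 to compound 4 (beyond the scatter).

No measured evidence bears on the reason for these steps. As far as these compounds go, whether an amine or a carboxylic acid on this phenyl would move the read-out beyond the scatter from compound 3 remains open.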